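This account rests on a few compounds, and the source may have more. Where it says the series, first, only, none or still open, it means among the compounds named here.

For the measured compounds named here, in a functional assay on HL-60 cells (Homo sapiens) for inhibition (a higher number here means a weaker inhibitor, a lower number a stronger inhibitor), three compounds with a shared core, differing only in one attached ring, have numbers so far. Compound 1 `OC[C@H]1OC(n2cnc3c(-c4ccoc4)ncnc32)[C@H](O)[C@@H]1O` gives 3300 nM and compound 2 `OC[C@H]1OC(n2cnc3c(-c4ccc(O)cc4)ncnc32)[C@H](O)[C@@H]1O` gives 7600 nM while compound 3 `Cn1cccc1-c1ncnc2c1ncn2C1O[C@H](CO)[C@@H](O)[C@H]1O` gives 15700 nM as the highest number, which makes it the weakest inhibitor of the three. The nearest gap is a 2.1-fold higher number from compound 2 to compound 3 (0.32 log units; beyond the scatter) and the widest is a 4.8-fold higher number from compound 1 to compound 3 (0.68 log units; beyond the scatter) while the remaining one is a 2.3-fold higher number from compound 1 to compound 2 (0.36 log units; beyond the scatter) in size.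

Compound 4 `OC[C@H]1OC(n2cnc3c(-c4nccs4)ncnc32)[C@H](O)[C@@H]1O` carries 1,3-thiazol-2-yl in place of 1-methyl-1H-pyrrol-2-yl on an aromatic carbon, and the count of what changes is 1,3-thiazol-2-yl in place of 1-methyl-1H-pyrrol-2-yl on an aromatic carbon here.

No thiazole has been measured, so the best guide is the same ring position in the three steps above, all of them modest. The closest comparison is compound 1 at 3300 nM. Its furan-3-yl, like the incoming group, is a five-membered ring without a methyl. A modest fall in this assay is therefore expected, estimated as a 2.6-fold lower number from compound 3 to compound 4 (0.42 log units; beyond the scatter) in size. For compound 4 the estimated value is 6000 nM with an expected range of 2000 nM to 16000 nM in this test.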

Compound 4, half-maximal inhibitory concentration: 6300 nM
The estimate for compound 4 lay 1.1-fold (0.02 log units) below the measured number; the range from low to high includes it.
By their numbers in this assay, from the lowest: compounds 1, 4 and 2 (each within the scatter of the next, the first and the last beyond it); then compound 3.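

In this assay, for the compounds shown here, putting 1,3-thiazol-2-yl in place of 1-methyl-1H-pyrrol-2-yl gives a change beyond the scatter (a 2.5-fold lower number from compound 3 to compound 4 (0.40 log units; beyond the scatter)), so swapping one five-membered aromatic ring for another at this position can matter, and compound 3 remains the only compound set apart from all the others. Compound 4 cannot be told apart from either neighbouring compound (a 1.2-fold lower number from compound 2 to compound 4 (0.08 log units; within the scatter); a 1.9-fold higher number from compound 1 to compound 4 (0.28 log units; within the scatter)), even though the step between those two neighbours lies beyond the scatter, so the thiazole fits within the range the other two rings span. Nothing measured here explains these differences.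

Compound 3 alone carries a methyl on its ring, so the effect of that methyl cannot be separated from that of the ring itself, and a methyl-bearing thiazole would address this. All four compounds carry an aromatic ring here, leaving open how an amine or a longer alkyl chain would behave at this position.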